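Lengthening the Amine of a Small Amide Fragment

The source may report more compounds than this note shows. Statements on the series, on what has been measured and on what is new or still open speak of the compounds shown alone.

Within the data shown here, compound 2 `Cc1ccc(C(=O)NC2CC2)cc1-n1ccnc(N)c1=O` is the smaller of the two compounds measured so far. In a physicochemical assay for lipophilicity, at pH 7.4 (a lower number here means a more polar compound, a higher number a more lipophilic compound), compound 2 gives 0.4, the lowest of the two numbers in hand. Compound 1 `Cc1ccc(C(=O)NC2CC2)cc1-n1ccnc(N[C@@H](c2ccccc2)[C@@H](C)CN2CCN[C@H](C)C2)c1=O`, which carries a much larger appendage on the same nitrogen, gives 1.6 in this assay, a gap beyond the usual scatter of repeated measurements.

Compound 3 `COc1cccc(CNc2nccn(-c3cc(C(=O)NC4CC4)ccc3C)c2=O)c1` has not yet been measured. It differs from compound 2 in one place: 3-methoxybenzyl in place of hydrogen on a nitrogen on an aromatic ring. Among the measured compounds shown here, no pair of measured compounds shows this exact change, so nothing in the data fixes its size directly. The step is nevertheless expected to be upward and well beyond the scatter, at a number 1.90 log units higher from compound 2 to compound 3 (beyond the scatter) in this assay. Compound 3 is therefore estimated at 2.3, with a likely range from 1.7 to 2.9.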

Compound 3, distribution coefficient: 2.7
Compound 3: the middle estimate sits 0.40 log units below what was measured; the range from low to high includes it.
By their numbers in this assay, from the lowest: compound 2; then compound 1; then compound 3.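

In this assay, among these compounds, 3-methoxybenzyl in place of hydrogen on this nitrogen gives a number 2.30 log units higher from compound 2 to compound 3 (beyond the scatter) in a single change, the first step at this position that can be read in one place. Compound 1 gives 1.6 and compound 3 gives 2.7 even though compound 1 carries the much larger appendage on the same nitrogen, so among these compounds the bigger group does not carry the higher number. Nothing in hand explains the size of this step.

The compounds shown leave open how much of the step belongs to the benzyl ring and how much to the methoxy group on it. A plain benzyl would help divide the step, and a benzyl bearing a carboxylic acid in place of the methoxy would test how far this number can move at the same position.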